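A few compounds are considered here, and "the series" means these few. Any claim that something is new, unique, unknown or untested is made for them only; others in the source may bear on it.

In a functional assay on HT-29 cells (Homo sapiens) for antiproliferative activity, read by MTT assay, with a stated time of 72 h (a lower number here means a stronger inhibitor, a higher number a weaker inhibitor), compound 1 (`CCCCn1ccnc1-c1cc(OC)c(OC)c(OC)c1`) gives > 100000 nM as a limit of the assay and not a number. Compound 2 (`COc1cc(-c2nccn2CC(C)C)cc(OC)c1OC`) gives > 100000 nM and this too is only a limit. Compound 3 (`COc1cc(-c2nccn2Cc2ccccc2)cc(OC)c1OC`) gives > 100000 nM and so also stands at a limit, with no number to place it. Going by the values given here, the series so far rests entirely on the limit of > 100000 nM in this assay, at which 3 of the 3 values shown sit, and offers no measured potency.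

Compound 4 (`COc1cc(-c2nccn2-c2ccc(C)cc2)cc(OC)c1OC`) has the same atoms as compound 3, joined differently: 4-methylphenyl in place of benzyl on an aromatic nitrogen. The change puts 4-methylphenyl in place of benzyl on an aromatic nitrogen.

The nearest measured changes are a step that the two limits leave unreadable from compound 1 to compound 3 and a step that the two limits leave unreadable from compound 2 to compound 3, with a step that the two limits leave unreadable from compound 1 to compound 2 as the third. All three changes concern groups on a saturated chain carbon bound to an aromatic nitrogen, and none has a readable size. No step size can therefore be carried over to compound 4, and any readable change from a limit in this assay could only point towards stronger inhibition.

The expected step is an at least 2.5-fold lower number from compound 3 to compound 4 (0.39 log units; beyond the scatter), and a further limit remains about as likely as a number. For compound 4, the estimated value is 40000 nM, within an expected range of 3000 nM to 100000 nM.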

Compound 4, half-maximal inhibitory concentration: 1600 nM
Beside the measured number, compound 4's estimate is 25-fold (1.40 log units) above it; measured number outside the range, below it.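

Compound 4 is the only compound shown that gives a number in this assay, so the group on the aromatic nitrogen can take this series off its limit, and this holds even with the atom count unchanged. Exchanging benzyl for 4-methylphenyl gives an at least 62-fold lower number from compound 3 to compound 4 (1.79 log units; beyond the scatter), while replacing the chain groups gives an at least 62-fold lower number from compound 2 to compound 4 (1.79 log units; beyond the scatter) and an at least 62-fold lower number from compound 1 to compound 4 (1.79 log units; beyond the scatter), so all three earlier groups fall well short of 4-methylphenyl at this position. These sizes are only lower bounds and the steps among compound 1, compound 2 and compound 3 cannot be read, so those three groups remain unranked, and the series still rests largely on one limit: the limit of > 100000 nM in this assay, at which 3 of the 4 values shown sit.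

With 4-methylphenyl as the only group of its kind on this nitrogen, the compounds shown do not separate the effect of attaching the aromatic ring to the nitrogen without a saturated carbon from that of its methyl group, a question that unsubstituted phenyl would address. They also leave open whether 4-methoxyphenyl, 4-chlorophenyl or a pyridine ring at this position would lower the number further or return it to the limit.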